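Bromoacrylamide series: phenethyl to chlorobenzyl at the thiazole side chain

The source may hold more compounds than are shown below. What is called first, only, known or untested is meant among the compounds shown, and "the series" means these compounds.

Measured compounds in a functional assay on L1210 cells (Mus musculus) for inhibition, read by cell counting, with a stated time of 2 days; on this read-out higher numbers stand for weaker inhibition and lower numbers for stronger inhibition:
compound 1 `COc1cccc(-c2nn3cc(-c4cccc(N)c4)nc3s2)c1` gives > 250000 nM.
compound 2 `C=C(Br)C(=O)Nc1cccc(-c2cn3nc(CCc4ccccc4)sc3n2)c1` gives 2200 nM.
compound 3 `COc1ccc(-c2csc3nc(-c4cccc(N)c4)cn23)cc1` gives 19000 nM.

For compound 1 the value > 250000 nM in this assay is a limit of the assay and not a number; this is stated as the limit of > 250000 nM in this assay, at which 1 of the 3 values shown sits. Of the two numbers shown, compound 2 with 2200 nM stands lowest in this assay; compound 3 gives 19000 nM, a higher number by a gap that lies beyond the usual scatter. Among the measured compounds shown here, no step between measured compounds differing in one place is available, so no measured effect of any single change is known here.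

Compound 4 `C=C(Br)C(=O)Nc1cccc(-c2cn3nc(Cc4ccc(Cl)cc4)sc3n2)c1` is yet to be measured in this assay. It differs from compound 2 as follows: 4-chlorophenyl in place of benzyl on a saturated chain carbon bound to an aromatic carbon. The bromoacrylamide on the aniline and the shared core are kept, only the side chain on the saturated carbon changes. With no measured step of this kind in hand, the expectation is a step from compound 2 to compound 4 of a 1.1-fold lower number from compound 2 to compound 4 (0.04 log units; within the scatter) in this assay, that is, none beyond the scatter. Compound 4 is therefore estimated at 2000 nM in this assay, within a range from 700 nM to 6000 nM.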

Compound 4, half-maximal inhibitory concentration: 2300 nM
Beside the measured number, compound 4's estimate is 1.2-fold (0.06 log units) below it; low and high end bracket the measured number.
By their numbers in this assay, from the lowest: compounds 2 and 4 (each within the scatter of the next); then compound 3. At a limit, above all of these: compound 1.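

In this assay the side chain on the saturated chain carbon bound to an aromatic carbon now has its first measured step, with phenethyl exchanged for 4-chlorobenzyl: a 1.0-fold higher number from compound 2 to compound 4 (0.02 log units; within the scatter). The earlier compounds shown here offered no pair differing in one place, whereas this pair shows that the read-out tolerates this exchange, with the bromoacrylamide on the aniline and the shared core kept. No measured property shown bears on this step.

Open, going by these compounds, is whether a longer chain, an amine or a carboxylic acid on the same saturated carbon would also stay within the scatter of compound 2, as one exchange says little about the position as a whole. The contribution of the bromoacrylamide also stays open, with no pair shown that differs there alone.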